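Swapping Furan-2-yl for 4-Methoxyphenyl at the Chain Carbon

The compounds below may be only part of what the source reports. "The series", "measured", "known", "first", "only" and "open" are said of these compounds alone.

Compound 1 `COc1ccc(CNC(=O)/C(C#N)=C/c2ccc[nH]2)cc1`, compound 2 `N#C/C(=C\c1ccco1)C(=O)NCc1ccc(Cl)c(Cl)c1` and compound 3 `COc1ccc(CNC(=O)/C(C#N)=C/c2ccoc2)cc1` share one core and were all tested in a functional assay on A2780 cells (Homo sapiens) for inhibition, read by MTT assay, with a stated time of 72 h; on this read-out higher numbers stand for weaker inhibition of growth and lower numbers for stronger inhibition of growth. In this assay compound 1 gives > 50000 nM, which is a limit of the assay and not a number. Compound 3 gives 6000 nM. Within the data shown here, the step of an at least 8.3-fold lower number from compound 1 to compound 3 (0.92 log units; beyond the scatter) is the only measured change at this position, and it lies beyond the scatter.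

In this assay compound 2 gives > 50000 nM, again a limit of the assay rather than a measured number. All that is known of compound 2 is the limit of > 50000 nM in this assay, at which 2 of the 3 values shown sit, so its true strength could sit anywhere weaker than that line.

Compound 4 `COc1ccc(/C=C(\C#N)C(=O)NCc2ccc(Cl)c(Cl)c2)cc1` differs from compound 2 by 4-methoxyphenyl in place of furan-2-yl on a double-bonded chain carbon bound to a double-bonded chain carbon. Among the measured compounds shown here, no measured pair makes this exact exchange; the nearest is an at least 8.3-fold lower number from compound 1 to compound 3 (0.92 log units; beyond the scatter), which replaced the group at the same place and moved the number beyond the scatter, though with different rings. Because compound 2 sits only at the limit of > 50000 nM in this assay, at which 2 of the 3 values shown sit, the step of an at least 2.5-fold lower number from compound 2 to compound 4 (0.39 log units; beyond the scatter) is expected to be downward at best by a modest amount, with wide uncertainty. Compound 4 is therefore estimated at 20000 nM, in a range from 3000 nM to 50000 nM.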

Compound 4, concentration for 50% growth inhibition: 86000 nM
Compound 4: the middle estimate sits 4.3-fold (0.63 log units) below what was measured, outside the stated range (above it).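

The step from compound 2 to compound 4 cannot be read, because compound 2 is known only as a limit of the assay and not as a number: the limit of > 50000 nM in this assay, at which 2 of the 4 values shown sit.

The compounds shown leave open how 4-methoxyphenyl and furan-2-yl truly compare on this double-bonded chain carbon in this assay.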